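This account rests on a few compounds, and the source may have more. Where it says the series, first, only, none or still open, it means among the compounds named here.

Working notes on the series. Compound 1 `CC1=C(C(=O)OC(C)(C)C)C(c2cccs2)NC(=O)N1` in an assay on membranes from HEK293 cells for displacement of a labelled ligand from adenosine receptor A2b (Homo sapiens), read by scintillation counting, with a stated time of 30 min, tested at 1 uM (on this read-out higher numbers stand for more inhibition at the one concentration tested (going by the name of the read-out) and lower numbers for less inhibition), gives 38%. Within the data shown here, compound 2 `CC1=C(C(=O)CC(C)C)C(c2cccs2)NC(=O)N1` in this assay gives 43%; the one measured step, a number 5 percentage points higher from compound 1 to compound 2 (within the scatter), is isobutyl in place of tert-butoxy on a carbonyl carbon and stays within the scatter. Compound 3 `CCN(CC)C(=O)C1=C(C)NC(=O)NC1c1ccco1` in this assay gives 31%, the lowest of the three numbers: its gap to compound 1 is within the scatter, its gap to compound 2 beyond it.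

Compound 4 `CCN(CC)C(=O)C1=C(C)NC(=O)NC1c1cccs1` differs from compound 3 by thiophen-2-yl in place of furan-2-yl on a saturated ring carbon. Among the measured compounds shown here, no measured step swaps these two rings. Compounds 1 and 2 both carry the thiophen-2-yl, but they differ from compound 3 on the carbonyl carbon as well, so their values show only where thiophene-bearing members of the shared core have landed, not the effect of the ring swap alone. The measured step of a number 5 percentage points higher from compound 1 to compound 2 (within the scatter) concerns the carbonyl side and gives no direction for this change. The expected step is a number 5 percentage points higher from compound 3 to compound 4 (within the scatter), a modest rise, because compound 1 gives 38% and compound 2 gives 43% with the thiophen-2-yl in place; this rests on few points and could as well be no step beyond the scatter. Compound 4 is therefore estimated at 36%, with a range from 24% to 48%.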

Compound 4, a percentage reported as inhibition, at one concentration (the size of the read-out at that concentration, not a potency): 22%
Estimate against measurement, compound 4: 14 percentage points above; measured number outside the range, below it.
By their numbers in this assay, from the lowest: compounds 4, 3, 1 and 2 (each within the scatter of the next, the first and the last beyond it).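

The swap of thiophen-2-yl for furan-2-yl on the saturated ring carbon next to the ring nitrogen now has a direct reading: with diethylamino on the carbonyl carbon, it gives a number 9 percentage points lower from compound 3 to compound 4 (within the scatter) in this assay and so does not separate the two rings on this read-out. With thiophen-2-yl held in place, the group on the carbonyl carbon does separate the compounds: diethylamino in place of isobutyl gives a number 21 percentage points lower from compound 2 to compound 4 (beyond the scatter) and diethylamino in place of tert-butoxy gives a number 16 percentage points lower from compound 1 to compound 4 (beyond the scatter), whereas the earlier step between isobutyl and tert-butoxy stayed within the scatter. Nothing available here accounts for either reading.

From the compounds shown here alone, it remains open whether the ring swap also stays within the scatter when isobutyl or tert-butoxy sits on the carbonyl carbon, since this reading rests on a single pair carrying diethylamino. Going by these compounds, it is equally open whether a smaller amine such as dimethylamino, a cyclic amine such as pyrrolidine, or a plain phenyl ring on the saturated ring carbon would fall with compound 4 or with compound 2 in this assay on this core.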